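This account rests on a few compounds, and the source may have more. Where it says the series, first, only, none or still open, it means among the compounds named here.

Measured in a functional assay on M21 cells (Homo sapiens) for antiproliferative activity, read by sulforhodamine B assay, with a stated time of 48 h; a higher number here means a weaker inhibitor, a lower number a stronger inhibitor:
- Compound 1 `O=C1NCCN1c1ccc(S(=O)(=O)Nc2ccc(F)c(F)c2)cc1`: 220 nM
- Compound 2 `Cc1cc(C)cc(NS(=O)(=O)c2ccc(N3CCNC3=O)cc2)c1`: 63 nM
- Compound 3 `Cc1cccc(NS(=O)(=O)c2ccc(N3CCNC3=O)cc2)c1C`: 110 nM

These compounds differ only in the group on a sulfonamide nitrogen. Compound 3 gives 110 nM, a value that cannot be separated from either of the other two, as the steps reaching it show: a 1.7-fold higher number from compound 2 to compound 3 (0.24 log units; within the scatter) and a 2.0-fold lower number from compound 1 to compound 3 (0.30 log units; within the scatter).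

Compound 4 `Cc1ccc(C)c(NS(=O)(=O)c2ccc(N3CCNC3=O)cc2)c1` has not yet been measured. It carries 2,5-dimethylphenyl in place of 2,3-dimethylphenyl on a sulfonamide nitrogen, so the two compounds have the same atoms, joined differently: 2,5-dimethylphenyl in place of 2,3-dimethylphenyl on a sulfonamide nitrogen.

The closest guide also exchanges one dimethylphenyl group for another, and it stayed small: a 1.7-fold higher number from compound 2 to compound 3 (0.24 log units; within the scatter). Among the measured compounds shown here, the only step that clears the scatter is a 3.5-fold lower number from compound 1 to compound 2 (0.54 log units; beyond the scatter), but it removes 3,4-difluorophenyl, and the change at hand involves no such group. With just one comparable pair, this is thin evidence, yet it points to no step beyond the scatter in this assay. The expected step is a 1.1-fold lower number from compound 3 to compound 4 (0.04 log units; within the scatter). The estimated value for compound 4 is 100 nM, with an expected range from 45 nM to 230 nM.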

Compound 4, half-maximal inhibitory concentration: 27 nM
The estimate for compound 4 lay 3.7-fold (0.57 log units) above the measured number; the measured number lies below the stated range.
By their numbers in this assay, from the lowest: compound 4; then compounds 2, 3 and 1 (each within the scatter of the next, the first and the last beyond it).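

In this assay, the swap at this sulfonamide nitrogen keeps the same atoms and only rearranges them, yet 2,5-dimethylphenyl in place of 2,3-dimethylphenyl gives a 4.1-fold lower number from compound 3 to compound 4 (0.61 log units; beyond the scatter), so carrying two methyl groups is not enough on its own to set the number, and their arrangement on the ring matters here. The 2,5-dimethylphenyl group also separates from the 3,5-dimethylphenyl group, with a 2.3-fold lower number from compound 2 to compound 4 (0.37 log units; beyond the scatter), even though the earlier exchange of one dimethylphenyl group for another stayed within the scatter, and the comparison with the difluorinated compound gives an 8.1-fold lower number from compound 1 to compound 4 (0.91 log units; beyond the scatter), which makes compound 4 the strongest inhibitor of the four. No measurement shown here accounts for this difference between arrangements.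

Going by these compounds, whether the effect belongs to the methyl groups themselves or to their arrangement in the 2,5-dimethylphenyl group stays open, and a 2,5-dichlorophenyl or 2,5-dimethoxyphenyl group on this nitrogen would help tell the two apart. It is also unknown whether the same order among the dimethylphenyl groups would hold with an amine or a carboxylic acid added to the shared core.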